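Oxygen to Sulfur Link on a Diamino Core

The source may report more compounds than this note shows. Statements on the series, on what has been measured and on what is new or still open speak of the compounds shown alone.

Measured compounds:
compound 1 `Nc1cc(N)c2nc(-c3ccccc3)c(Oc3ccc(Cl)c(Cl)c3)nc2c1` – < 100000 nM
compound 2 `CCOC(=O)[C@H](CCC(=O)O)NC(=O)c1ccc(CNc2nc3cc(N)cc(N)c3nc2-c2ccccc2)cc1` – 93300 nM

In a functional assay on SR cells (Homo sapiens) for inhibition, read by sulforhodamine B assay, with a stated time of 48 h (on this read-out lower numbers stand for higher toxicity in this test and higher numbers for lower toxicity in this test), compound 1 is reported only as a limit, < 100000 nM, not as a measured number. What the data show for compound 1 is the limit of < 100000 nM in this assay, at which 1 of the 2 values shown sits, so its true toxicity in this assay is not pinned down. Compound 2, which carries a different side group on the same core, gives 93300 nM in this assay, a weak effect.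

Compound 3 `Nc1cc(N)c2nc(-c3ccccc3)c(Sc3ccc(Cl)c(Cl)c3)nc2c1` differs from compound 1 by (3,4-dichlorophenyl)sulfanyl in place of 3,4-dichlorophenoxy on an aromatic carbon. Among the measured compounds shown here, no measured pair in this set carries such a change, and for this assay the step is expected to be small, with no clear direction beyond the usual scatter. Compound 3 is therefore expected near 60000 nM, with a likely span from 15000 nM to 150000 nM. The expected step is a step that the limit leaves unreadable from compound 1 to compound 3.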

Compound 3, concentration lethal to 50% of the cells: < 100000 nM
Compound 3: only a limit was reported; the forecaster's own chance of this, stated with the estimate: 40%; the middle value does not contradict the limit.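

Compound 1 and compound 3 are each reported only as a limit in this assay, so no step can be read between them: the limit of < 100000 nM in this assay, at which 2 of the 3 values shown sit.

The compounds shown leave open how toxic either one truly is, and whether (3,4-dichlorophenyl)sulfanyl in place of 3,4-dichlorophenoxy changes that toxicity at all.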